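The source may hold more compounds than are shown below. What is called first, only, known or untested is meant among the compounds shown, and "the series" means these compounds.

Working notes on the series. Three members have been run in a functional assay on SK-MEL-28 cells (Homo sapiens) for inhibition, read by sulforhodamine B assay, with a stated time of 48 h; a lower number here means a stronger inhibitor of growth, a higher number a weaker inhibitor of growth. Compound 1 `COc1ccc(-c2[nH]c3ccccc3c2/C=C(\C#N)S(=O)(=O)c2ccccc2)cc1` gives 1800 nM; compound 2 `CC(=O)/C(=C\c1c(-c2ccccc2)[nH]c2ccccc12)S(=O)(=O)c1ccccc1` gives 2000 nM; compound 3 `COc1ccc2[nH]c(-c3ccccc3)c(/C=C(\C#N)S(=O)(=O)c3ccccc3)c2c1` gives 6100 nM. Going by the values given here, on these three numbers compound 3 stands highest: its nearest neighbour is compound 2 and its furthest is compound 1, and both of those gaps lie beyond the scatter, so compound 3 is the weakest growth inhibitor of the three measured so far.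

Compound 4 `N#C/C(=C\c1c(-c2ccccc2)[nH]c2ccccc12)S(=O)(=O)c1ccccc1` remains to be measured in this assay. It differs from compound 3 in one place: hydrogen in place of methoxy on an aromatic carbon. Among the compounds with values here, no pair of measured compounds isolates this change, so its size is not fixed by the data. Compound 1 and compound 2, which carry no methoxy at that place, both sit lower than compound 3 in this assay, so a downward step, beyond the scatter, is expected. The expected step is a 2.4-fold lower number from compound 3 to compound 4 (0.39 log units; beyond the scatter). Compound 4 is estimated at 2500 nM, within a range from 1000 nM to 6000 nM.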

Compound 4, concentration for 50% growth inhibition: 8300 nM
Beside the measured number, compound 4's estimate is 3.3-fold (0.52 log units) below it; measured number outside the range, above it.
By their numbers in this assay, from the lowest: compounds 1 and 2 (each within the scatter of the next); then compounds 3 and 4 (each within the scatter of the next).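

In this assay, hydrogen in place of methoxy on the aromatic carbon of the fused system gives a 1.4-fold higher number from compound 3 to compound 4 (0.13 log units; within the scatter), so the two groups cannot be told apart at this place. The same exchange at the different aromatic carbon that carries the methoxy in compound 1 gives a 4.6-fold higher number from compound 1 to compound 4 (0.66 log units; beyond the scatter), so among these compounds the methoxy registers at that carbon and not on the fused system. Cyano in place of acetyl on the double-bonded chain carbon gives a 4.2-fold higher number from compound 2 to compound 4 (0.62 log units; beyond the scatter), a modest step that shows this chain carbon also moves the number when no methoxy is present.

Nothing on hand explains why these steps differ in size. Still open, on these data alone, is whether a hydroxyl, an amine or a longer alkoxy chain on the fused system would separate from hydrogen and methoxy, and whether a carboxylic acid could stand in for cyano or acetyl on the chain carbon.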